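The compounds below may be only part of what the source reports. "The series", "measured", "known", "first", "only" and "open" are said of these compounds alone.

Measured compounds:
- Compound 1, `CC1CCN(c2c(S(=O)(=O)c3cc(F)cc(F)c3)cnc3cc(Cl)ccc23)CC1`, gives 195 nM in an assay on isolated protein for displacement of a labelled ligand from metabotropic glutamate receptor 5 (Homo sapiens), with a stated time of 60 min; a lower number here means a stronger inhibitor, a higher number a weaker inhibitor.
- Compound 2, `NC(=O)C1CCN(c2c(S(=O)(=O)c3ccccc3)cnc3ccccc23)CC1`, gives "not determined" (no result reported) in this assay.

Compound 2 therefore stands nowhere on the numbers: nothing in this assay tells how strongly it displaces the labelled ligand. Within the data shown here, the only measured anchor is compound 1, which shares the general build of an aromatic core carrying a sulfone and a piperidine but differs from compound 2 in several places, so its value can only be read as a rough guide.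

Compound 3, `CC1CCN(c2c(S(=O)(=O)c3ccccc3)cnc3ccccc23)CC1`, is made from compound 2 by a single change: methyl in place of carbamoyl on a saturated ring carbon. Among the measured compounds shown here, with no measured pair showing the effect of this change, no size of step can be read from the data; the change is expected to move the inhibition constant little, within the usual scatter, or at most modestly in either direction.

Compound 3 is estimated to give 600 nM, with a plausible range from 150 nM to 3000 nM.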

Compound 3, inhibition constant: 108 nM
Beside the measured number, compound 3's estimate is 5.6-fold (0.74 log units) above it, outside the stated range (below it).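

No step can be read from compound 2 to compound 3, as compound 2 has no number to compare. The compounds shown leave open how far, and in which direction, going from 4-carbamoylpiperidin-1-yl to 4-methylpiperidin-1-yl shifts the inhibition constant. No supporting evidence bears on this result.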